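Cytotoxicity notes: pyrimidinyl replacement on the imidazopyridinone

A few compounds are considered here, and "the series" means these few. Any claim that something is new, unique, unknown or untested is made for them only; others in the source may bear on it.

Measured compounds in an ADME assay on HeLa cells (Homo sapiens) for cytotoxicity, read by ATP content, with a stated time of 3 days; on this read-out higher numbers stand for lower toxicity in this test and lower numbers for higher toxicity in this test:
- compound 1 `O=c1n(Cc2cc3cnccc3n2CCCC(F)(F)F)c2cnccc2n1C1CC1`: compound 1 gives > 50000 nM
- compound 2 `O=c1n(Cc2cc3cc(Cl)ccc3n2CCCCO)c2cnccc2n1C1CC1`: compound 2 gives > 50000 nM
- compound 3 `N#CCCCn1c(Cn2c(=O)n(-c3ccc(C(=O)NC4CC4)cc3)c3ccncc32)cc2cc(Cl)ccc21`: compound 3 gives > 50000 nM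

All three values are limits of this assay and not numbers. Compound 3 therefore stands at the limit, and it cannot be placed above or below compound 1 or compound 2 on the numbers shown; the three compounds sit together at the limit of > 50000 nM in this assay, at which 3 of the 3 values shown sit. Among the measured compounds shown here, no step between measured compounds can be computed here.

Compound 4 `N#CCCCn1c(Cn2c(=O)n(-c3ncccn3)c3ccncc32)cc2cc(Cl)ccc21` is not yet measured. It differs from compound 3 by pyrimidin-2-yl in place of 4-(cyclopropylcarbamoyl)phenyl on an aromatic nitrogen. The rest of the molecule, including the chain carrying the nitrile and the chlorine on the fused ring, is kept.

Given that compound 3 stands at the limit with > 50000 nM, the change is expected to produce no step beyond the scatter in this assay. The expected step is a number no higher from compound 3 to compound 4 (the limit leaves the size open), none beyond the scatter. Compound 4 is expected to give 50000 nM in this assay, with a range of 20000 nM to 50000 nM, and most likely again only a limit rather than a number.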

Compound 4, half-maximal cytotoxic concentration: > 50000 nM
Compound 4 was reported as a limit (the forecaster's own chance of this, stated with the estimate: 85%); the middle value lies on the limit itself.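

In this assay compound 4 gives > 50000 nM, which is a limit and not a number. Compound 3 also stands at a limit, so no step from compound 3 to compound 4 can be read: the limit of > 50000 nM in this assay, at which 4 of the 4 values shown sit.

The compounds shown leave open whether pyrimidin-2-yl in place of 4-(cyclopropylcarbamoyl)phenyl alters cytotoxicity at all, and at what concentration any of them would reach the half-maximal cytotoxic effect.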